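Swapping a ring amine on two related peroxide cores

A few compounds are considered here, and "the series" means these few. Any claim that something is new, unique, unknown or untested is made for them only; others in the source may bear on it.

Compound 1 `O=C(C[C@H]1CC[C@]2(CC1)OO[C@]1(O2)C2CC3CC(C2)CC1C3)N1CCNCC1` and compound 3 `O=C(C[C@@H]1CCC[C@]2(C1)OOC1(O2)C2CC3CC(C2)CC1C3)N1CCNCC1` share the same atoms joined differently; the difference between the two cores is not broken down here. In an ADME assay on microsomes from liver (Mus musculus) for metabolic stability (a lower number here means slower removal, a higher number faster removal of the compound), compound 1 gives 14.4 uL/min, and compound 3 gives 27.2 uL/min. Compound 2 `NC1CCN(C(=O)C[C@H]2CC[C@]3(CC2)OO[C@]2(O3)C3CC4CC(C3)CC2C4)CC1` carries the change (4-aminopiperidin-1-yl in place of piperazin-1-yl on a carbonyl carbon), and in this assay compound 2 gives 2.5 uL/min, a step of a 5.8-fold lower number from compound 1 to compound 2 (0.76 log units; beyond the scatter). Compound 4 `NC1CCN(C(=O)C[C@@H]2CCC[C@]3(C2)OOC2(O3)C3CC4CC(C3)CC2C4)CC1` is not yet measured; it differs from compound 3 by 4-aminopiperidin-1-yl in place of piperazin-1-yl on a carbonyl carbon, the same change made on the other core. Because the only shown instance of this change is a 5.8-fold lower number from compound 1 to compound 2 (0.76 log units; beyond the scatter), the step from compound 3 to compound 4 in this assay is expected to be of similar size, a 5.8-fold lower number from compound 3 to compound 4 (0.76 log units; beyond the scatter). Compound 4 is therefore estimated at 4.7 uL/min, with a likely range from 2 uL/min to 12 uL/min.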

Compound 4, intrinsic clearance in a liver preparation (reported as CLH), per the amount of preparation that the assay uses: 8.2 uL/min
Compound 4: middle estimate off by 1.7-fold (0.24 log units), on the low side; the measured number falls inside the stated range.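

In this assay, putting 4-aminopiperidin-1-yl in place of piperazin-1-yl on the second core gives a 3.3-fold lower number from compound 3 to compound 4 (0.52 log units; beyond the scatter). Set beside the earlier step, the two sizes agree: the same change on two cores in this assay, a 5.8-fold lower number (0.76 log units; beyond the scatter) from compound 1 to compound 2 and a 3.3-fold lower number (0.52 log units; beyond the scatter) from compound 3 to compound 4, 1.7-fold (0.24 log units) apart, within the scatter of two such steps. On these two cores, then, the change carries over in direction and in roughly the same size, but two pairs cannot show that it would hold on a further core, and they do not explain why the number falls.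

The compounds shown leave open how other groups would behave at this place on a carbonyl carbon, such as morpholin-4-yl or an open-chain amine in place of piperazin-1-yl.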